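The compounds below may be only part of what the source reports. "The series", "measured", "known", "first", "only" and "open" are said of these compounds alone.

- Compound 1 `CCOc1ccc(Nc2c(-c3ccc(OC)cc3)c(=O)oc3cc(OC)ccc23)cc1`: 36100 nM
- Compound 2 `COc1ccc(-c2c(Nc3cccc(C(F)(F)F)c3)c3ccc(OC)cc3oc2=O)cc1`: 39500 nM

In a functional assay on PANC-1 cells (Homo sapiens) for antiproliferative activity, read by MTT assay, with a stated time of 48 h (a lower number here means a stronger inhibitor, a higher number a weaker inhibitor), compound 2 gives 39500 nM, which cannot be told apart from the value of compound 1. Compound 3 `COc1ccc(-c2c(Nc3cccc(C(F)(F)F)c3)c3ccc(O)cc3oc2=O)cc1` differs from compound 2 by one change, hydrogen in place of methyl on an oxygen on an aromatic ring, or methoxy to hydroxy. Among the compounds with values here, the only measured step, a 1.1-fold higher number from compound 1 to compound 2 (0.04 log units; within the scatter), lies within the scatter and concerns a different group, so no measurement tests this change directly. No clear shift in either direction is therefore expected in this assay. The expected change is a 1.3-fold lower number from compound 2 to compound 3 (0.12 log units; within the scatter). For compound 3 the estimated value is 30000 nM, with an expected range from 10000 nM to 75000 nM.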

Compound 3, half-maximal inhibitory concentration: 67200 nM
Estimate against measurement, compound 3: 2.2-fold (0.35 log units) below; low and high end bracket the measured number.
By their numbers in this assay, from the lowest: compounds 1, 2 and 3 (each within the scatter of the next).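

Replacing methoxy with hydroxy, with hydrogen in place of methyl on an oxygen on an aromatic ring, gives a 1.7-fold higher number from compound 2 to compound 3 (0.23 log units; within the scatter) in this assay. Within the data shown here, this is the first direct test of this position, and the two compounds cannot be told apart, so neither group shows a clear advantage here. Nothing measured here offers an explanation for this result. Still open, as far as these compounds go, is whether a longer chain on that oxygen, or an amine in its place, would move the number beyond the scatter. From the compounds shown here alone, whether the same swap behaves alike with other groups on the nitrogen also remains open.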